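Methyl added next door to the chloro in a urea series

The source may report more compounds than this note shows. Statements on the series, on what has been measured and on what is new or still open speak of the compounds shown alone.

Measured compounds:
- compound 1 `COc1cccc(NC(=O)NC2=NC(=O)CN2C)c1`: 2800 nM
- compound 2 `O=C(NC1=NC(=O)C2CCCN12)Nc1cccc(Cl)c1`: 800 nM
- compound 3 `O=C(NC1=NC(=O)C2CCCN12)Nc1ccccc1`: 4200 nM

In a functional assay for inhibition of metabotropic glutamate receptor 5 (Homo sapiens), read by FLIPR and calcium flux (a higher number here means a weaker inhibitor, a lower number a stronger inhibitor), compound 2 gives the lowest number of the three: compound 1 gives 2800 nM and compound 3 gives 4200 nM, both beyond the scatter above compound 2. The only single-point step among these is a 5.3-fold higher number from compound 2 to compound 3 (0.72 log units; beyond the scatter), which shows that the chloro on the aromatic ring of compound 2 carries a modest part of its potency.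

Compound 4 `Cc1ccc(NC(=O)NC2=NC(=O)C3CCCN23)cc1Cl` keeps the chloro and the shared core of compound 2 and differs only by methyl in place of hydrogen on an aromatic carbon. Going by the values given here, no measured step bears directly on a methyl at this position; the one step on record, a 5.3-fold higher number from compound 2 to compound 3 (0.72 log units; beyond the scatter), concerns the chloro and says nothing about a further substituent beside it. The expectation must therefore be cautious: the chloro is retained, so the loss seen from compound 2 to compound 3 should not recur, and the methyl is expected to leave the number within or near the scatter of compound 2. Compound 4 is estimated at 650 nM in this assay, in the range 200 nM to 2000 nM, a step of a 1.2-fold lower number from compound 2 to compound 4 (0.09 log units; within the scatter) that is expected to stay close to the scatter.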

Compound 4, half-maximal inhibitory concentration: > 10000 nM
Compound 4 gave a limit, no number (the forecaster's own chance of this, stated with the estimate: 5%); at least 15-fold (1.18 log units) between middle value and limit.
By their numbers in this assay, from the lowest: compound 2; then compounds 1 and 3 (each within the scatter of the next). At a limit, above all of these: compound 4.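

In this assay, methyl in place of hydrogen on this aromatic carbon, ortho to a chloro group and para to a large group, is a large step in the wrong direction: an at least 12-fold higher number from compound 2 to compound 4 (1.09 log units; beyond the scatter). Going by these compounds alone, compound 2 and compound 4 both carry the chloro, so keeping that group does not preserve activity once the methyl enters, and this position matters in a way the earlier compounds could not show; they offered only the modest step for the chloro itself, a 5.3-fold higher number from compound 2 to compound 3 (0.72 log units; beyond the scatter). Compound 4 gives > 10000 nM, which is a limit of the assay and not a number: the limit of > 10000 nM in this assay, at which 1 of the 4 values shown sits.

The compounds shown leave open whether a fluoro or an amine on this same aromatic carbon would bring a similar loss, and so whether the loss is particular to methyl or extends to any replacement of the hydrogen here. They also leave open whether a methyl at this carbon would have the same result without the chloro, and how far the true value of compound 4 lies past its limit.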